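Trifluoromethoxy to benzyloxy: a step starting from a limit

This account rests on a few compounds, and the source may have more. Where it says the series, first, only, none or still open, it means among the compounds named here.

Compound 1 `O=[N+]([O-])c1cn2c(n1)S(=O)(=O)CC(Oc1ccc(C(F)(F)F)cn1)C2`: 46000 nM
Compound 2 `O=[N+]([O-])c1cn2c(n1)SCC(OCc1ccc(OC(F)(F)F)cc1)C2`: > 64000 nM (a limit)
Compound 3 `O=[N+]([O-])c1cn2c(n1)S(=O)(=O)CC(OCc1ccc(OCc3ccccc3)cc1)C2`: > 64000 nM (a limit)

All three results come from an ADME assay on MRC5 cells (Homo sapiens) for cytotoxicity (a lower number here means a stronger inhibitor, a higher number a weaker inhibitor), and only compound 1 has an actual number. Compound 2 is reported only as a limit, > 64000 nM, and so has no exact value (the limit of > 64000 nM in this assay, at which 2 of the 3 values shown sit). Compound 3 is likewise reported only as a limit, > 64000 nM, and it also carries a benzyloxy group.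

Compound 4 `O=[N+]([O-])c1cn2c(n1)SCC(OCc1ccc(OCc3ccccc3)cc1)C2` is the unmeasured partner of compound 2, and the change between them is benzyl in place of trifluoromethyl on an oxygen on an aromatic ring. In words, the trifluoromethoxy group of compound 2 gives way to a benzyloxy group in compound 4. Among the compounds with values here, no measured pair isolates this change, so the expectation in this assay remains cautious, with no shift beyond the scatter. The estimated change is an at least 1.0-fold lower number from compound 2 to compound 4 (0.02 log units; that floor lies within the scatter) and it is expected to be small. For compound 4 the expected value is 60000 nM, with an estimated range from 30000 nM to 90000 nM as its span.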

Compound 4, half-maximal inhibitory concentration: > 64000 nM
Compound 4: a limit, no number (the forecaster's own chance of this, stated with the estimate: 65%); at least 1.0-fold (0.02 log units) between middle value and limit.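

Within the data shown here, compound 4 is reported only as a limit (> 64000 nM), as is compound 2, so no step between compound 2 and compound 4 can be read: the limit of > 64000 nM in this assay, at which 3 of the 4 values shown sit.

The compounds shown leave open what effect, if any, trifluoromethoxy to benzyloxy has on this read-out.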